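The source may report more compounds than this note shows. Statements on the series, on what has been measured and on what is new or still open speak of the compounds shown alone.

Compound 1 `ClCc1ccccc1Cn1cnc2c(Cl)nc(Cl)nc21` is the reference point of this small set. In a functional assay on K562 cells (Homo sapiens) for cytotoxicity, read by sulforhodamine B assay, with a stated time of 48 h (a higher number here means that more compound is tolerated, a lower number that less compound is tolerated), compound 1 gives 910 nM. Compound 2 `ClCc1cccc(Cn2cnc3c(Cl)nc(Cl)nc32)c1` is built from the same atoms joined differently; the difference between the two cores is not broken down here. For compound 2 this assay reports only a limit, > 100000 nM. Compound 3 `Nc1nc(Cl)c2ncn(Cc3ccccc3CCl)c2n1` differs from compound 1 by amino in place of chloro on an aromatic carbon. For compound 3 this assay again reports only a limit, > 100000 nM. The measured step of an at least 100-fold higher number from compound 1 to compound 3 (2.04 log units; beyond the scatter) is therefore a large one, and two of the three results sit at the limit of > 100000 nM in this assay, at which 2 of the 3 values shown sit.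

Compound 4 `Nc1nc(Cl)c2ncn(Cc3cccc(CCl)c3)c2n1` has not yet been measured. Going by the values given here, it differs from compound 2 by amino in place of chloro on an aromatic carbon, which is the same change as the one that separates compound 3 from compound 1, at the same place in the shared core. The expectation for compound 4 rests on two things: the earlier change produced an at least 100-fold higher number from compound 1 to compound 3 (2.04 log units; beyond the scatter), and compound 2, the starting point, already stands at a limit of > 100000 nM. In this assay compound 4 is thus expected to give 150000 nM, with a range from 100000 nM to 500000 nM, and most probably only a limit rather than a number will be reported. The step expected is a step that the limit leaves unreadable from compound 2 to compound 4, small beside the earlier one only because the starting point already sits at the limit of > 100000 nM in this assay, at which 2 of the 3 values shown sit.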

Compound 4, concentration lethal to 50% of the cells: > 100000 nM
Compound 4 gave a limit, no number; the forecaster's own chance of this, stated with the estimate: 90%; the middle value lies beyond the limit too.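

Compound 2 and compound 4 both give only a limit in this assay, so no step can be read between them for amino in place of chloro on an aromatic carbon: the limit of > 100000 nM in this assay, at which 3 of the 4 values shown sit.

The compounds shown leave open how far beyond that limit compound 2 and compound 4 lie, and so whether this change acts on compound 2 as it does on compound 1.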